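A few compounds are considered here, and "the series" means these few. Any claim that something is new, unique, unknown or untested is made for them only; others in the source may bear on it.

Compound 1 `Cc1nc(C)c([C@H](OC(C)(C)C)C(=O)O)c(N2CCC(C)(C)CC2)c1-c1ccc(OCCc2ccc(F)cc2F)cc1`: 1.08 h
Compound 2 `Cc1nc(C)c([C@H](OC(C)(C)C)C(=O)O)c(N2CCC(C)(C)CC2)c1-c1ccc(OCCCc2ccc(F)cc2)cc1`: > 2 h
Compound 3 `Cc1nc(C)c([C@H](OC(C)(C)C)C(=O)O)c(N2CCC(C)(C)CC2)c1-c1ccc(SCCc2ccc(F)cc2)cc1`: > 2 h

In an ADME assay on microsomes from liver (Homo sapiens) for metabolic stability, read by LC-MS, tested at 0.5 uM (on this read-out lower numbers stand for a shorter-lived compound and higher numbers for a longer-lived compound), compound 3 gives > 2 h, which is a limit of the assay and not a number. Two of the three values sit at that limit (the limit of > 2 h in this assay, at which 2 of the 3 values shown sit). The steps of an at least 1.8-fold higher number from compound 1 to compound 3 (0.26 log units; that floor lies within the scatter) and an at least 1.8-fold higher number from compound 1 to compound 2 (0.26 log units; that floor lies within the scatter) each end at the limit, so only a floor of their size is known, and the step that the two limits leave unreadable from compound 2 to compound 3 cannot be read at all.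

Compound 4 `Cc1nc(C)c(CCOc2ccc(-c3c(C)nc(C)c([C@H](OC(C)(C)C)C(=O)O)c3N3CCC(C)(C)CC3)cc2)s1` differs from compound 3 in one place: 2-(2,4-dimethyl-1,3-thiazol-5-yl)ethoxy in place of (2-(4-fluorophenyl)ethyl)sulfanyl on an aromatic carbon. Going by the values given here, no measured step exchanges the aromatic ring of this side chain, so none bears directly on the change; the step from compound 1 to compound 3 touches the same position, and its oxygen-to-sulfur part is reversed here. With compound 3 at the limit, a number can only appear if the value falls under the limit, and the measured steps fix no direction. For compound 4 the value in this assay is expected near the limit, estimated at 1.5 h (range 0.7 h to 3 h). That corresponds to an expected step of an at least 1.3-fold lower number from compound 3 to compound 4 (0.12 log units; that floor lies within the scatter), within the scatter.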

Compound 4, half-life: 0.917 h
Estimate against measurement, compound 4: 1.6-fold (0.21 log units) above; the range from low to high includes it.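

In this assay, going by these compounds alone, 2-(2,4-dimethyl-1,3-thiazol-5-yl)ethoxy on this aromatic carbon gives the first steps at this position that are printed as beyond the scatter (an at least 2.1-fold lower number from compound 3 to compound 4 (0.33 log units; beyond the scatter); an at least 2.1-fold lower number from compound 2 to compound 4 (0.33 log units; beyond the scatter)). Both steps start from a limit of the assay and not a number, so their sizes are floors only: the limit of > 2 h in this assay, at which 2 of the 4 values shown sit. Against compound 1, with its 2,4-difluorophenyl on the same ethoxy chain, the exchange for 2,4-dimethyl-1,3-thiazol-5-yl stays within the scatter (a 1.2-fold lower number from compound 1 to compound 4 (0.07 log units; within the scatter)).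

The step between compound 2 and compound 3 remains unreadable, and the step from compound 3 changes the aromatic ring and the sulfanyl link together, so the two parts cannot be separated. A 2-(4-fluorophenyl)ethoxy group or a 2-(2,4-dimethyl-1,3-thiazol-5-yl)ethylsulfanyl group would divide them, and a 3-(2,4-dimethyl-1,3-thiazol-5-yl)propoxy group would test the longer chain with this ring.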